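A few compounds are considered here, and "the series" means these few. Any claim that something is new, unique, unknown or untested is made for them only; others in the source may bear on it.

Measured in a functional assay (blood) for inhibition, with Homo sapiens as the target; a higher number here means a weaker inhibitor, a lower number a stronger inhibitor:

- Compound 1 `CC(C)(C)Sc1c(CC(C)(C)C(=O)O)n(Cc2ccc(Cl)cc2)c2ccc(CCc3ccc4ccccc4n3)cc12`: > 3000 nM
- Compound 2 `CC(C)(C)Sc1c(CC(C)(C)C(=O)O)n(Cc2ccc(Cl)cc2)c2ccc(OCc3ccc4cc(F)c(F)cc4n3)cc12`: > 3000 nM
- Compound 3 `CC(C)(C)Sc1c(CC(C)(C)C(=O)O)n(Cc2ccc(Cl)cc2)c2ccc(OCc3ccc4cccnc4n3)cc12`: > 3000 nM

Each of these entries is a limit of the assay and not a number. Compound 3 therefore has no exact position, and the same is true of the other two.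

Compound 4 `COc1ccc2nc(COc3ccc4c(c3)c(SC(C)(C)C)c(CC(C)(C)C(=O)O)n4Cc3ccc(Cl)cc3)sc2c1` keeps the rest of compound 3 and makes one change: a group of 11 heavy atoms (8 carbon, 1 nitrogen, 1 oxygen, 1 sulfur; one five-membered aromatic ring with 2 hetero atoms, one six-membered aromatic ring of carbon only) in place of a group of 10 heavy atoms (8 carbon, 2 nitrogen; 2 six-membered aromatic rings with 1 hetero atom each), on a saturated chain carbon bound to an oxygen on an aromatic ring. The entering group is 6-methoxy-1,3-benzothiazol-2-yl.

Within the data shown here, two measured steps bear on this change. The closer one is a step that the two limits leave unreadable from compound 2 to compound 3, a swap at the same place. The other is a step that the two limits leave unreadable from compound 1 to compound 3, a swap of a larger piece on an aromatic carbon. Among the measured compounds shown here, neither gives a size that could be carried over, so no definite step can be predicted.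

Compound 4 is expected to remain weak because the limit of > 3000 nM in this assay, at which 3 of the 3 values shown sit, is all that the measured compounds show. The expected change is a step that the limit leaves unreadable from compound 3 to compound 4, and it is uncertain. For compound 4 the estimated value is 4000 nM, with an expected range from 1500 nM to 12000 nM.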

Compound 4, half-maximal inhibitory concentration: 670 nM
Beside the measured number, compound 4's estimate is 6.0-fold (0.78 log units) above it; the whole stated range lies above it.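

In this assay, a change on the saturated chain carbon bound to an oxygen on an aromatic ring can bring a compound off the limit and give a real number: 6-methoxy-1,3-benzothiazol-2-yl produces an at least 4.4-fold lower number from compound 3 to compound 4 (0.65 log units; beyond the scatter). The same group produces an at least 4.4-fold lower number from compound 2 to compound 4 (0.65 log units; beyond the scatter), so the gain appears against two different leaving groups, and both sizes are minimums, with a limit at the starting end. The steps among the earlier compounds cannot be read, and compound 4 is the only one shown with an exact value: the limit of > 3000 nM in this assay, at which 3 of the 4 values shown sit.

Going by these compounds, it remains open whether a plain 1,3-benzothiazol-2-yl group, or one carrying a chlorine in place of the methoxy, would keep this gain. A 1,3-benzoxazol-2-yl group would show whether the sulfur of the five-membered ring matters.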